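This account rests on a few compounds, and the source may have more. Where it says the series, first, only, none or still open, it means among the compounds named here.

Compound 3 `Cc1nc(C(=O)NO)c(N)c2c1C(=O)N(Cc1ccccc1)C2=O` carries a hydroxycarbamoyl group on the shared core. In an ADME assay on Vero cells (Chlorocebus sabaeus) for cytotoxicity, read by MTT assay (a lower number here means a stronger inhibitor, a higher number a weaker inhibitor), compound 3 stands at "not determined" (no result reported), so no number of its own places it. Compound 2 `Cc1nc(C(N)=O)c(N)c2c1C(=O)N(Cc1ccccc1)C2=O` likewise shows "not determined" (no result reported) in this assay. Compound 1 `CCOC(=O)c1nc(C)c2c(c1N)C(=O)N(Cc1ccccc1)C2=O` reaches only a limit of the assay, > 100000 nM in this assay, and not a number. Compound 4 `Cc1noc(-c2nc(C)c3c(c2N)C(=O)N(Cc2ccccc2)C3=O)n1` differs from compound 3 by 3-methyl-1,2,4-oxadiazol-5-yl in place of hydroxycarbamoyl on an aromatic carbon. Going by the values given here, no measured step tells what this change does; the expected step in this assay is none beyond the scatter, in neither direction. The expectation rests on compound 1 alone, which sits at the limit of > 100000 nM in this assay, at which 1 of the 3 values shown sits. For compound 4 the estimated value in this assay is 100000 nM, between 30000 nM and 300000 nM.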

Compound 4, half-maximal inhibitory concentration: > 100000 nM
Compound 4: no number, only a limit; the forecaster's own chance of this, stated with the estimate: 70%; the middle value sits exactly at the limit.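

Compound 1 and compound 4 both stop at a limit of the assay and give no number, so no step between them can be read in this assay: the limit of > 100000 nM in this assay, at which 2 of the 4 values shown sit.

The compounds shown leave open whether any group at this place on the shared core changes the result in this assay.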